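The source may hold more compounds than are shown below. What is called first, only, known or untested is meant among the compounds shown, and "the series" means these compounds.

Measured in an in vivo ADME assay on the whole organism (strain 129/SvEvBrd x C57BL/6) for pharmacokinetics, with Mus musculus as the target; a lower number here means that a smaller share of the oral dose reaches the circulation, a higher number that a larger share of the oral dose reaches the circulation:
- compound 1 `CN(C)C(=O)c1nc([C@@H](O)[C@H](O)[C@H](O)CO)c[nH]1` gives 5%
- compound 2 `OC[C@@H](O)[C@@H](O)[C@H](O)c1c[nH]c(C(F)(F)C(F)(F)F)n1` gives 31%
- compound 3 `OC[C@@H](O)[C@@H](O)[C@H](O)c1c[nH]c(-c2ncn(Cc3ccccc3)n2)n1` gives 6%

Compound 1 (5%) lies within the scatter of compound 3, and compound 2 (31%) lies beyond the scatter of both, with the higher number. Compound 4 `OC[C@@H](O)[C@@H](O)[C@H](O)c1c[nH]c(-c2cnccn2)n1` has pyrazin-2-yl in place of dimethylcarbamoyl on an aromatic carbon and awaits measurement in this assay. Within the data shown here, no measured pair isolates this change, so any expectation is loose. The nearest guide is compound 3 (6%), which also carries a ring-bearing group at this place. The expected step of a number 5 percentage points higher from compound 1 to compound 4 (within the scatter) is a small rise, not beyond the scatter. For compound 4 the estimate is 10% with an expected range of 3% to 30% as estimated.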

Compound 4, oral bioavailability: 10%
For compound 4 middle estimate and measured number coincide at the digits printed; the range from low to high includes it.
By their numbers in this assay, from the lowest: compounds 1, 3 and 4 (each within the scatter of the next); then compound 2.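

In this assay, pyrazin-2-yl in place of dimethylcarbamoyl gives a number 5 percentage points higher from compound 1 to compound 4 (within the scatter), the first step read directly at this place. Exchanging a group with no ring for a six-membered aromatic ring with 2 hetero atoms on this aromatic carbon therefore leaves the number within the usual scatter. Nothing available accounts for the size of this step.

Open, on these data alone, is what a carboxylic acid, an amine or a longer alkyl chain would give on this aromatic carbon. Also open, as far as these compounds go, is which feature of the group in compound 2, at 31%, sets it apart.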